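The compounds below may be only part of what the source reports. "The series", "measured", "known", "first", "only" and "open" are said of these compounds alone.

Measured compounds:
compound 1, `COc1cccc(CCC(=O)N2CCN(c3ccc(C(F)(F)F)cc3[C@@H](N)CC(C)C)CC2)c1`, 4000 nM
compound 2, `CCC(C)[C@H](NCCN)c1cc(C(F)(F)F)ccc1N1CCN(C(=O)CCc2ccc(Cl)cc2Cl)CC1`, 56 nM

Of the compounds shown here, two have been measured in an assay on HEK293 cells for displacement of a labelled ligand from Melanocortin receptor 4 (Homo sapiens); a higher number here means a weaker inhibitor, a lower number a stronger inhibitor. Compound 1 `COc1cccc(CCC(=O)N2CCN(c3ccc(C(F)(F)F)cc3[C@@H](N)CC(C)C)CC2)c1` gives 4000 nM in this assay. Compound 2 `CCC(C)[C@H](NCCN)c1cc(C(F)(F)F)ccc1N1CCN(C(=O)CCc2ccc(Cl)cc2Cl)CC1` gives 56 nM, the lowest of the two numbers; compound 1 sits far above it, and the gap between the two lies well beyond the usual scatter. Among the measured compounds shown here, no single-point step between the two measured compounds is available, since they differ in more than one place, so the data say only what the two values show.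

Compound 3 `CC(C)C[C@H](NC(=O)CN)c1cc(C(F)(F)F)ccc1N1CCN(C(=O)CCc2ccc(Cl)cc2Cl)CC1` has not been measured. It differs from compound 2 in one place: 1-(((aminomethyl)carbonyl)amino)-3-methylbutyl in place of 1-((2-aminoethyl)amino)-2-methylbutyl on an aromatic carbon. The rest of the molecule is kept unchanged from compound 2.

For the measured compounds named here, with no measured step to lean on, the expectation rests on compound 2 alone, which gives 56 nM. The exchange keeps the donor and acceptor counts and the chain length roughly as before, so a small shift in this assay is expected, if any, most likely toward a somewhat higher number: the step from compound 2 to compound 3 is estimated at a 2.7-fold higher number from compound 2 to compound 3 (0.43 log units; beyond the scatter). Compound 3 is therefore expected to give about 150 nM in this assay, within a range from 40 nM to 600 nM.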

Compound 3, inhibition constant: 19 nM
Compound 3: middle estimate off by 7.9-fold (0.90 log units), on the high side; measured number below the stated range.
By their numbers in this assay, from the lowest: compound 3; then compound 2; then compound 1.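

In this assay, among the compounds shown here, the exchange on this aromatic carbon, ortho to a large group and meta to a trifluoromethyl group, gives a 2.9-fold lower number from compound 2 to compound 3 (0.47 log units; beyond the scatter) and so provides the first reading of a single change at this position. A modest but real move toward a lower number accompanies the replacement of 1-((2-aminoethyl)amino)-2-methylbutyl by 1-(((aminomethyl)carbonyl)amino)-3-methylbutyl, with the rest of the molecule unchanged and the same counts of hydrogen-bond donors and acceptors printed for both groups, so this position accepts a carbonyl in the chain without any loss in this measure. Nothing available explains the direction or the size of this shift.

The step alters the carbonyl and the place of the methyl branch together, so the compounds shown cannot assign it to either one, and a pairing of the 1-((2-aminoethyl)amino) chain with the 3-methylbutyl skeleton would be needed to separate them. Also open, on these data alone, is how the number responds at the far end of the chain, where a carboxylic acid or a dimethylamine could stand in place of the primary amine, or to a longer chain between that amine and the carbonyl.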